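A few compounds are considered here, and "the series" means these few. Any claim that something is new, unique, unknown or untested is made for them only; others in the source may bear on it.

Of the compounds shown here, three have been measured in an assay for displacement of a labelled ligand from corticotropin-releasing factor receptor 1 (Homo sapiens); a lower number here means a stronger inhibitor, a higher number a weaker inhibitor. Compound 1 `CCN(CC)C(=O)c1sc(Nc2c(Cl)cc(Cl)cc2Cl)nc1C` gives 5000 nM in this assay, and compound 2 `CCCN(CC1CC1)C(=O)c1sc(Nc2c(C)cc(C)cc2C)nc1C` gives 2600 nM. Compound 3 `CCCN(Cc1sc(Nc2c(C)cc(C)cc2Br)nc1C(F)(F)F)CC1CC1` gives 21 nM, the lowest of the three numbers; its distances to compound 2 and to compound 1 both lie beyond the scatter, so compound 3 is the strongest inhibitor among them. Among the compounds with values here, compound 3 and compound 2 share the cyclopropylmethyl and propyl substituents on the nitrogen, but differ in the core and in the aryl group, so no single step between them can be read off.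

Compound 4 `CCCN(Cc1sc(Nc2c(C)cc(Cl)cc2C)nc1C(F)(F)F)CC1CC1` differs from compound 3 in one place: 4-chloro-2,6-dimethylphenyl in place of 2-bromo-4,6-dimethylphenyl on a nitrogen on an aromatic ring. Both groups carry one halogen and two methyls on the same ring, and their counted atoms, donors and acceptors are alike. Within the data shown here, no measured pair shows the effect of such a swap, so the step is expected to be small, in no clear direction, and most likely within the scatter. The step from compound 3 to compound 4 in this assay is expected to be a 1.3-fold higher number from compound 3 to compound 4 (0.12 log units; within the scatter). Compound 4 is therefore estimated at 28 nM, with a range from 9 nM to 90 nM.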

Compound 4, inhibition constant: 73 nM
Beside the measured number, compound 4's estimate is 2.6-fold (0.42 log units) below it; the measured number falls inside the stated range.
By their numbers in this assay, from the lowest: compound 3; then compound 4; then compounds 2 and 1 (each within the scatter of the next).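

In this assay, within the data shown here, placing 4-chloro-2,6-dimethylphenyl where 2-bromo-4,6-dimethylphenyl stood on a nitrogen on an aromatic ring gives a 3.5-fold higher number from compound 3 to compound 4 (0.54 log units; beyond the scatter), the only step between compounds differing in one place. This position therefore distinguishes between these two aryl groups, even though they match in their count of heavy atoms and each has no hydrogen-bond donors or acceptors. Nothing measured here accounts for the step.

The swap changes both the halogen and the pattern of groups on the ring, so the compounds shown cannot separate the contribution of either change. As far as these compounds go, it also remains open how a methoxy group or a nitrile would fare on this ring, and whether the same swap would give a similar step on the core of compound 2.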